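A few compounds are considered here, and "the series" means these few. Any claim that something is new, unique, unknown or untested is made for them only; others in the source may bear on it.

Measured in a functional assay on MCF7 cells (Homo sapiens) for antiproliferative activity, read by sulforhodamine B assay, with a stated time of 72 h (on this read-out lower numbers stand for stronger inhibition and higher numbers for weaker inhibition), so far:
Compound 1 `O=C(/C=C/c1csc2ccccc12)c1cc(Br)ccc1O` gives 1040 nM here
Compound 2 `O=C(/C=C/c1csc2ccccc12)c1cc(Br)cc(Br)c1O` gives 5800 nM here

Compound 1 holds the lower of the two numbers in this assay and so shows the stronger inhibition. Among the measured compounds shown here, the single measured step, a 5.6-fold higher number from compound 1 to compound 2 (0.75 log units; beyond the scatter), comes with bromo in place of hydrogen on an aromatic carbon.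

Compound 3 `CCOc1ccc(O)c(C(=O)/C=C/c2csc3ccccc23)c1` has not been measured. Its difference from compound 1 is ethoxy in place of bromo on an aromatic carbon, para to a hydroxy group. For the measured compounds named here, no measured step exchanges this bromo for anything, so a 5.6-fold higher number from compound 1 to compound 2 (0.75 log units; beyond the scatter) is only a loose guide to size. A modest step at most is expected in this assay, with no firm direction and a slight lean to a higher number. The expected change is a 1.4-fold higher number from compound 1 to compound 3 (0.16 log units; within the scatter). For compound 3 the estimate is 1500 nM, with an expected range from 500 nM to 5000 nM.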

Compound 3, half-maximal inhibitory concentration: 7500 nM
Compound 3: middle estimate off by 5.0-fold (0.70 log units), on the low side; the whole stated range lies below it.
By their numbers in this assay, from the lowest: compound 1; then compounds 2 and 3 (each within the scatter of the next).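

In this assay, ethoxy in place of bromo on the aromatic carbon para to a hydroxy group brings a 7.2-fold higher number from compound 1 to compound 3 (0.86 log units; beyond the scatter), so this place does not accept the exchange without loss. Neither single change tried on compound 1 lowers the number: the added bromo of the earlier step gave a 5.6-fold higher number from compound 1 to compound 2 (0.75 log units; beyond the scatter), and compound 1 remains the strongest of the three in this assay. The data shown offer no measured explanation for the rise at this position.

On these data alone, it remains open whether the rise belongs to ethoxy itself or would follow any exchange of this bromo. A chloro group, a methoxy group, an amine or a longer chain at this place could settle that, and the compounds shown say nothing about what any of them would give.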